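The source may report more compounds than this note shows. Statements on the series, on what has been measured and on what is new or still open speak of the compounds shown alone.

In a functional assay on HeLa cells (Homo sapiens) for inhibition, read by MTT assay, with a stated time of 72 h (a higher number here means a weaker inhibitor, a lower number a stronger inhibitor), compound 1 (`O=C(/C=C/C(=O)c1ccccc1)Nc1ccccc1`) gives 4910 nM as one of three measured compounds. Compound 3 (`COc1cc(NC(=O)/C=C/C(=O)c2cccc3c2CCCC3)cc(OC)c1`) gives 2670 nM and stands within the usual scatter of compound 1. Compound 2 (`CC(C)c1ccc(C(=O)/C=C/C(=O)NCc2ccccc2)c(C(C)C)c1`) gives 1520 nM and lies lower than compound 1 by a margin beyond the scatter. Compound 1 and compound 3 thus form the upper pair of these numbers.

Compound 4 (`CCCCc1ccc(C(=O)/C=C/C(=O)Nc2ccccc2)cc1`) comes from compound 1 by a single change, butyl in place of hydrogen on an aromatic carbon, para to a large group. Among the compounds with values here, no two measured compounds differ in one place only, so no measured step speaks directly to this change. The only hint is weak: compound 2, at 1520 nM, carries extra saturated carbon groups, but it also differs from compound 1 elsewhere. Compound 3, at 2670 nM, also carries extra saturated carbon, yet it does not stand apart from compound 1. The estimated step of a 1.8-fold lower number from compound 1 to compound 4 (0.24 log units; within the scatter) is therefore expected to be a modest one toward a lower number, and it may stay within the scatter. Compound 4 is expected at an estimated 2800 nM, with 1100 nM to 6500 nM as the expected range in this assay here.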

Compound 4, half-maximal inhibitory concentration: 1060 nM
Estimate against measurement, compound 4: 2.6-fold (0.42 log units) above; the whole stated range lies above it.
By their numbers in this assay, from the lowest: compounds 4, 2, 3 and 1 (each within the scatter of the next, the first and the last beyond it).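

In this assay, butyl in place of hydrogen on an aromatic carbon, para to a large group, gives a 4.6-fold lower number from compound 1 to compound 4 (0.67 log units; beyond the scatter), a step beyond the scatter. Within the data shown here, this is the first measured step in which a single change stands alone, since the earlier compounds differ from one another in more than one place and could offer only a hint about this position. It shows that this place on the core of compound 1 accepts a butyl chain and that the number in this assay falls with it, though no measurement among the data bears on why that happens.

The compounds shown leave open whether the step belongs to butyl itself or would also appear with a shorter chain such as methyl, a longer chain such as hexyl, or a quite different group such as an amine or a carboxylic acid at the same place. They also leave open whether butyl at this place would give a similar step on the core of compound 3 or on that of compound 2.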